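Methoxy in place of fluoro on the fused ring

A few compounds are considered here, and "the series" means these few. Any claim that something is new, unique, unknown or untested is made for them only; others in the source may bear on it.

Measured compounds:
- compound 1, `CS(=O)(=O)c1ccc(Nc2ncc(F)c(Nc3nc4ccccc4s3)n2)cc1`, 3170 nM
- compound 2, `Cc1ccc2nc(Nc3nc(Nc4ccc(S(C)(=O)=O)cc4)ncc3F)sc2c1`, 17200 nM
- compound 3, `CS(=O)(=O)c1ccc(Nc2ncc(F)c(Nc3nc4ccc(F)cc4s3)n2)cc1`, > 50000 nM

The three compounds share one core and differ only in one substituent on the fused ring. In a functional assay on HeLa cells (Homo sapiens) for antiproliferative activity, read by MTT assay, with a stated time of 48 h (a lower number here means a stronger inhibitor, a higher number a weaker inhibitor), compound 1 gives 3170 nM and is the most potent of the three. Adding a methyl gives a 5.4-fold higher number from compound 1 to compound 2 (0.73 log units; beyond the scatter). For compound 3 the assay reports only a limit, > 50000 nM, so compound 3 stands at the weak end, at the limit of > 50000 nM in this assay, at which 1 of the 3 values shown sits. The fluoro substitution gives an at least 15-fold higher number from compound 1 to compound 3 (1.19 log units; beyond the scatter), and exchanging methyl for fluoro gives an at least 2.9-fold higher number from compound 2 to compound 3 (0.46 log units; beyond the scatter).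

Compound 4, `COc1ccc2nc(Nc3nc(Nc4ccc(S(C)(=O)=O)cc4)ncc3F)sc2c1`, carries a methoxy where compound 3 carries fluoro: methoxy in place of fluoro on an aromatic carbon. Within the data shown here, no measured step covers methoxy at this position, so the expectation rests on the neighbouring substituents: the methyl of compound 2 weakened the inhibitor modestly, the fluoro of compound 3 strongly. Methoxy is expected to behave closer to methyl than to fluoro, giving an expected at least 2.0-fold lower number from compound 3 to compound 4 (0.30 log units; that floor lies within the scatter). Compound 4 is therefore estimated at 25000 nM, within 6000 nM to 100000 nM, with a real chance that only a limit is reported.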

Compound 4, half-maximal inhibitory concentration: 25400 nM
Compound 4: the middle estimate sits 1.0-fold (0.01 log units) below what was measured, and the stated range covers the measured number.
By their numbers in this assay, from the lowest: compound 1; then compounds 2 and 4 (each within the scatter of the next). At a limit, above all of these: compound 3.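

With methoxy added, hydrogen remains the substituent with the lowest number at this position: the change gives an 8.0-fold higher number from compound 1 to compound 4 (0.90 log units; beyond the scatter), so methyl, fluoro and methoxy all weaken the inhibitor relative to hydrogen. Exchanging methyl for methoxy gives a 1.5-fold higher number from compound 2 to compound 4 (0.17 log units; within the scatter), so these two groups cannot be told apart in this assay. Exchanging fluoro for methoxy gives an at least 1.9-fold lower number from compound 3 to compound 4 (0.29 log units; that floor lies within the scatter), and that step is only a floor, because one end of it is a limit: the limit of > 50000 nM in this assay, at which 1 of the 4 values shown sits.

The compounds shown leave open whether a different kind of group, such as an amine or a carboxylic acid, would bring the number back towards that of compound 1, 3170 nM. Also open, on these data alone, is whether a longer chain such as ethoxy would match methoxy, and whether methoxy would act the same on the other carbons of this ring.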